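Swapping a flexible diamine for a pyridylmethyl amine

A few compounds are considered here, and "the series" means these few. Any claim that something is new, unique, unknown or untested is made for them only; others in the source may bear on it.

Measured so far:
- Compound 1 `CN(C)CCN(CCN(C)C)c1ccc(C(=O)N2CCc3ccc(OS(N)(=O)=O)cc3C2)cc1` gives 15.9% in an assay on HEK293 cells for inhibition of Steryl-sulfatase (Homo sapiens), tested at 1 uM; on this read-out lower numbers stand for a weaker effect and higher numbers for a stronger effect at the one concentration tested.
- Compound 2 `CCN(Cc1ccccc1)c1cccc(C(=O)N2CCc3ccc(OS(N)(=O)=O)cc3C2)c1` gives 69% in this assay.
- Compound 3 `NS(=O)(=O)Oc1ccc2c(c1)CN(C(=O)c1cccc(N3CCN(c4ncccn4)CC3)c1)CC2` gives 24.4% in this assay.

All three share the same core and differ only in the amine attached to the aromatic ring of the amide. Compound 1 has the smallest of the three numbers; compound 3 lies within the usual scatter of it, so these two cannot be told apart, while compound 2 lies well beyond it.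

Compound 4 `CCN(Cc1cccnc1)c1ccc(C(=O)N2CCc3ccc(OS(N)(=O)=O)cc3C2)cc1` has not yet been measured. Its difference from compound 1 is ethyl((pyridin-3-yl)methyl)amino in place of bis(2-(dimethylamino)ethyl)amino on an aromatic carbon. For the measured compounds named here, no measured pair shows this exact change. Compound 2, which also carries an ethyl group and an aromatic arm on the amine, gives 69%, and compound 4 comes closer to that arrangement than compound 1 does, so a step upward beyond the scatter is expected. In this assay compound 4 is estimated at 50%, with a range from 25% to 75%. The expected step is a number 34.1 percentage points higher from compound 1 to compound 4 (beyond the scatter).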

Compound 4, a percentage reported as inhibition, at one concentration (the size of the read-out at that concentration, not a potency): 85.2%
For compound 4 the middle estimate is 35.2 percentage points below the measured one; measured number outside the range, above it.
By their numbers in this assay, from the lowest: compounds 1 and 3 (each within the scatter of the next); then compound 2; then compound 4.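

At the aromatic carbon para to a large group, putting ethyl((pyridin-3-yl)methyl)amino in place of bis(2-(dimethylamino)ethyl)amino gives a number 69.3 percentage points higher from compound 1 to compound 4 (beyond the scatter) in this assay. For the compounds shown here, the earlier compounds offered no pair differing in one place, so this is the first direct sign that the amine at this position alone can move the read-out by a wide margin on an unchanged core. The change swaps an open chain with no ring for a group carrying a six-membered aromatic ring with one hetero atom, and it also alters the heavy-atom and acceptor counts, but nothing measured here separates these changes or explains the rise.

Going by these compounds, it remains open which part of the new group carries the step, the ethyl arm or the (pyridin-3-yl)methyl arm. A propyl group in place of the ethyl, or a (pyridin-2-yl)methyl or (pyridin-4-yl)methyl arm in place of the (pyridin-3-yl)methyl, would test each part on its own at this same position.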